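The compounds below may be only part of what the source reports. "The series", "measured", "known", "first", "only" and "open" are said of these compounds alone.

In an assay on isolated protein for inhibition of retinal dehydrogenase 2 (Homo sapiens) (a lower number here means a stronger inhibitor, a higher number a weaker inhibitor), three compounds have been measured. Compound 1 `CC(Sc1nc2c(cnn2C)c(=O)n1-c1ccccc1)c1cccc(F)c1` gives 110 nM. Compound 2 `Cn1ncc2c(=O)n(-c3ccccc3)c(OCc3cccc(F)c3)nc21` gives 3700 nM, and compound 3 `CC(Sc1nc2nn(C3COC3)cc2c(=O)n1-c1ccccc1)c1ccccn1` gives 21 nM. Among these three numbers compound 1 stands second highest: compound 3 lies at a lower number and compound 2 at a higher one, and both of these gaps are larger than the usual scatter of repeated measurements, so compound 3 is the stronger inhibitor of the three and compound 2 the weaker.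

Compound 4 `CC(Sc1nc2c(cnn2C)c(=O)n1-c1ccccc1)c1cccnc1` has not yet been measured in this assay. It differs from compound 1 in one place: pyridin-3-yl in place of 3-fluorophenyl on a saturated chain carbon bound to a saturated chain carbon and a sulfur. Within the data shown here, no measured pair shows this same change on its own. Compound 3 differs from compound 1 in more than one place, so the value of compound 3, 21 nM, cannot be read as the effect of this change alone. The expected step is a 1.2-fold higher number from compound 1 to compound 4 (0.07 log units; within the scatter), small and possibly within the scatter, with no firm direction. Compound 4 is therefore estimated to give 130 nM, with a range from 45 nM to 400 nM.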

Compound 4, half-maximal inhibitory concentration: 89 nM
Compound 4: the middle estimate sits 1.5-fold (0.16 log units) above what was measured, within the range that was stated.
By their numbers in this assay, from the lowest: compound 3; then compounds 4 and 1 (each within the scatter of the next); then compound 2.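

In this assay, pyridin-3-yl in place of 3-fluorophenyl on this saturated chain carbon gives a 1.2-fold lower number from compound 1 to compound 4 (0.09 log units; within the scatter), the only comparison shown that isolates a single change at this position. In this one pair, an aromatic ring with one hetero atom and one hydrogen-bond acceptor stands where an all-carbon ring carrying fluorine stood, with no difference that can be told from the scatter of the assay. Nothing measured here bears on why the two compounds read alike.

The compounds shown leave open how this position responds to groups of another kind, such as a cyclohexyl ring, a phenyl ring bearing a carboxylic acid, or a longer chain ending in an amine. They also leave open whether this same swap gives a similar step on a different core.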